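This account rests on a few compounds, and the source may have more. Where it says the series, first, only, none or still open, it means among the compounds named here.

Measured so far:
Compound 1, `O=C(N/N=C/c1ccccc1)c1cccnc1`: in an ADME assay on MT4 cells (Homo sapiens) for cytotoxicity, read by MTT assay, with a stated time of 4 days (a higher number here means that more compound is tolerated, a lower number that less compound is tolerated), compound 1 gives > 125 ug/mL, which is a limit of the assay and not a number.
Compound 2, `O=C(N/N=C/c1ccc(Br)cc1)c1cccnc1`: in this assay compound 2 gives 61 ug/mL.

Compound 2 thus holds the only number shown in this assay; the one further value shown is a limit, recorded as the limit of > 125 ug/mL in this assay, at which 1 of the 2 values shown sits. Among the compounds with values here, the single measured step runs from the unsubstituted parent to the bromo compound, an at least 2.0-fold lower number from compound 1 to compound 2 (0.31 log units; beyond the scatter), a modest but real drop in tolerated concentration.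

Compound 3, `O=C(N/N=C/c1ccc(F)cc1)c1cccnc1`, differs from compound 2 by fluoro in place of bromo on an aromatic carbon, the fluorine sitting on an aromatic carbon of a six-membered aromatic ring of carbon only, para to a large group. Within the data shown here, only that one step bears on the change, and it bears on it indirectly: it shows what bromo did relative to hydrogen, not what fluoro does relative to bromo. Since bromo leaves, part of that modest step may be undone, but no data show how much. Compound 3 is therefore expected to sit at 95 ug/mL, within 50 ug/mL to 125 ug/mL, an expected step of a 1.6-fold higher number from compound 2 to compound 3 (0.19 log units; within the scatter), at most modest and possibly within the scatter.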

Compound 3, half-maximal cytotoxic concentration: > 125 ug/mL
Compound 3 was reported as a limit (the forecaster's own chance of this, stated with the estimate: 40%); at least 1.3-fold (0.11 log units) between middle value and limit.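

Exchanging bromo for fluoro on the aromatic carbon para to a large group gives, in this assay, an at least 2.0-fold higher number from compound 2 to compound 3 (0.31 log units; beyond the scatter), so among the two halogens shown at this place, only bromo comes with the lower number. The earlier step could not make this distinction, since it set bromo against hydrogen alone and left open whether any halogen here would lower the number. Fluoro in place of hydrogen cannot be read as a step, and compound 2 remains the only compound with a number, while compound 1 and compound 3 stand at the same limit, which is a limit of the assay and not a number: the limit of > 125 ug/mL in this assay, at which 2 of the 3 values shown sit.

As far as these compounds go, how far compound 1 and compound 3 lie from that limit, and whether they differ from each other at all, stays unknown, so any effect of fluoro relative to hydrogen remains open. Also open, from the compounds shown here alone, is whether chloro, iodo, methyl, methoxy or an amine on the same aromatic carbon would follow bromo or fluoro, and whether bromo on another carbon of that ring would give the same lower number.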